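Nitro-Bearing Ring Variant Weighed Against Its Fluoro Parent

The source may hold more compounds than are shown below. What is called first, only, known or untested is meant among the compounds shown, and "the series" means these compounds.

Three measured compounds share one core and differ only in the aromatic ring at the far end. Compound 1 `CC(C)[C@H](NC(=O)COc1cccc2ccccc12)C(=O)N[C@@H](CC(=O)O)C(=O)COc1cccc(F)c1` gives 12000 nM in a functional assay with Homo sapiens as the target (on this read-out lower numbers stand for stronger inhibition and higher numbers for weaker inhibition), the lowest of the three numbers. Compound 2 `CC(C)[C@H](NC(=O)COc1cccc2ccccc12)C(=O)N[C@@H](CC(=O)O)C(=O)COc1cc(F)ccc1F` gives 19700 nM, and the step of a 1.6-fold higher number from compound 1 to compound 2 (0.22 log units; within the scatter) comes from fluoro in place of hydrogen on an aromatic carbon. Compound 3 `CC(C)[C@H](NC(=O)COc1cccc2ccccc12)C(=O)N[C@@H](CC(=O)O)C(=O)COc1c(F)c(F)c(-c2c(F)c(F)c(F)c(F)c2F)c(F)c1F` gives 40000 nM, the furthest from compound 1. Compound 4 `CC(C)[C@H](NC(=O)COc1cccc2ccccc12)C(=O)N[C@@H](CC(=O)O)C(=O)COc1ccc([N+](=O)[O-])cc1F` has not yet been measured; it differs from compound 1 by 2-fluoro-4-nitrophenyl in place of 3-fluorophenyl on an oxygen on a saturated carbon. Within the data shown here, only the step to compound 2 bears on this change, and it stayed within the scatter, so no step beyond the scatter is expected, with at most a slight lean toward a higher number. Compound 4 is therefore expected to give 16000 nM, between 6000 nM and 42000 nM, an expected step of a 1.3-fold higher number from compound 1 to compound 4 (0.12 log units; within the scatter).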

Compound 4, half-maximal inhibitory concentration: 15800 nM
Compound 4: middle estimate off by 1.0-fold (0.01 log units), on the high side; the measured number falls inside the stated range.
By their numbers in this assay, from the lowest: compounds 1, 4 and 2 (each within the scatter of the next); then compound 3.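

In this assay, 2-fluoro-4-nitrophenyl on the oxygen gives a 1.3-fold higher number from compound 1 to compound 4 (0.12 log units; within the scatter), and set against the 2,5-difluorophenyl it gives a 1.2-fold lower number from compound 2 to compound 4 (0.10 log units; within the scatter). So this position takes a nitro group, with its added atoms and hydrogen-bond acceptors, without a step beyond the scatter, which the fluoro-only rings could not show. Nothing shown explains why the numbers stay this close. Since the nitro group enters as the fluoro moves, the two changes cannot be separated here. As far as these compounds go, whether an amine or a carboxylic acid on this ring would also stay within the scatter remains open.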